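A few compounds are considered here, and "the series" means these few. Any claim that something is new, unique, unknown or untested is made for them only; others in the source may bear on it.

Working notes on the series in a functional assay on the whole organism with Mus musculus as the target; on this read-out higher numbers stand for an effect only at larger amounts of compound and lower numbers for an effect already at smaller amounts. For the measured compounds named here, compound 1 `CN(C)C(=O)Cn1c(-c2ccccc2)nc2cccnc21` gives 35 mg/kg, the only single number available so far, and it is the anchor for everything that follows. Compound 2 `CN(C)C(=O)Cn1c(-c2cccc(Cl)c2)nc2cccnc21` is reported only as limits, > 56.2 mg/kg; < 100 mg/kg (2 entries).

Compound 3 `COc1ccc(-c2nc3cccnc3n2CC(=O)N(C)C)cc1` keeps the shared core and the side chain of compound 1. Going by the values given here, its one change is methoxy in place of hydrogen on an aromatic carbon, para to a large group: methoxy in place of hydrogen on an aromatic carbon. Among the compounds with values here, no measured step gauges such a change, so the expectation rests on compound 1 at 35 mg/kg. No shift beyond the usual scatter is expected, with a slight lean towards larger doses. The expected step is a 1.3-fold higher number from compound 1 to compound 3 (0.11 log units; within the scatter). For compound 3 the estimated dose is 45 mg/kg, with an expected range of 20 mg/kg to 100 mg/kg.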

Compound 3, dose for half-maximal effect: 39.5 mg/kg
Compound 3: the middle estimate sits 1.1-fold (0.06 log units) above what was measured; low and high end bracket the measured number.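

In this assay, for the compounds shown here, methoxy in place of hydrogen on an aromatic carbon, para to a large group, gives the first readable step, a 1.1-fold higher number from compound 1 to compound 3 (0.05 log units; within the scatter), so compound 1 and compound 3 cannot be told apart on this read-out. Going by these compounds alone, this position therefore carries methoxy without a shift beyond the scatter, which the earlier compounds could not show. No measurement at hand gives a reason for this result or ties it to a property of methoxy.

On these data alone, whether an amine or a carboxylic acid at this same position would also leave the dose unchanged stays open. Compound 2 stands only as a limit (> 56.2 mg/kg; < 100 mg/kg (2 entries)) and not as a number, so its step cannot be read.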